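The source may report more compounds than this note shows. Statements on the series, on what has been measured and on what is new or still open speak of the compounds shown alone.

Compound 1 `COc1ccc(N(C(=O)CN2C=CN(c3ccccc3)C(=O)[C@@H](Cc3n[nH]c4ccccc34)C2=O)C(C)C)cc1` gives 1550 nM in a functional assay on CHO cells for agonist activity at Melanocyte-stimulating hormone receptor (Homo sapiens), read by a luciferase reporter, with a stated time of 4 h; on this read-out lower numbers stand for an effect already at smaller amounts and higher numbers for an effect only at larger amounts of compound; among the three measured compounds it stands second highest. Compound 2 `CC(C)N(C(=O)CN1C=CN(C)C(=O)C(Cc2n[nH]c3cc(F)ccc23)C1=O)c1ccc(F)cc1` gives 3720 nM, and compound 3 `COc1ccc(N(C(=O)CN2C=CN(c3ccccc3)C(=O)C(Cc3n[nH]c4ccccc34)C2=O)C(C)C)cc1` gives 29.5 nM. Among the measured compounds shown here, the only single-place step, a 53-fold lower number from compound 1 to compound 3 (1.72 log units; beyond the scatter), involves no change of atoms or bonds; it rests on (the fact that one of compounds 1 and 3 is drawn with a defined configuration and the other without, at the place where they differ). Compound 4 `O=C1[C@H](Cc2n[nH]c3ccccc23)C(=O)N(c2ccccc2)C=CN1CC(=O)N1CCCCc2ccccc21` keeps the drawn configuration of compound 1 and differs by a group of 11 heavy atoms (10 carbon, 1 nitrogen; one six-membered aromatic ring of carbon only, one seven-membered non-aromatic ring with 1 hetero atom) in place of a group of 12 heavy atoms (10 carbon, 1 nitrogen, 1 oxygen; one six-membered aromatic ring of carbon only), on a carbonyl carbon. For the measured compounds named here, no measured step touches that part of the structure, so none of the steps bears on it, and the expected step from compound 1 is taken as small, a 1.3-fold lower number from compound 1 to compound 4 (0.11 log units; within the scatter). Compound 4 is therefore estimated at 1200 nM, within a wide range from 250 nM to 6000 nM.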

Compound 4, half-maximal effective concentration: 61.7 nM
The estimate for compound 4 lay 19-fold (1.29 log units) above the measured number; measured number outside the range, below it.
By their numbers in this assay, from the lowest: compound 3; then compound 4; then compound 1; then compound 2.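

Among the compounds shown here, the group on the carbonyl carbon, which no earlier step touched, turns out to matter: with the drawn configuration kept, a seven-membered ring group in place of isopropyl(4-methoxyphenyl)amino gives a 25-fold lower number from compound 1 to compound 4 (1.40 log units; beyond the scatter). A high number in compound 1 is therefore not fixed by its drawn configuration alone. Nothing given here explains the size of this step.

From the compounds shown here alone, whether the seven-membered ring or the loss of the oxygen counts most stays open. So does how a piperidine or morpholine would read on this carbonyl carbon.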